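Aryl variation at the five-membered ring of a nucleoside core

A few compounds are considered here, and "the series" means these few. Any claim that something is new, unique, unknown or untested is made for them only; others in the source may bear on it.

Three members of the series share one core and differ in the aryl group on an aromatic carbon of the five-membered ring. Compound 1 `O=c1[nH]cnc2c1c(-c1ccoc1)cn2[C@@H]1O[C@H](CO)[C@@H](O)[C@H]1O` carries furan-3-yl and in a functional assay on K562 cells (Homo sapiens), read by MTT assay, with a stated time of 72 h (on this read-out higher numbers stand for weaker inhibition and lower numbers for stronger inhibition), compound 1 gives 14500 nM. Compound 2 `O=c1[nH]cnc2c1c(-c1cccs1)cn2[C@@H]1O[C@H](CO)[C@@H](O)[C@H]1O` carries thiophen-2-yl; its result in this assay is a limit, > 20000 nM. Compound 3 `O=c1[nH]cnc2c1c(-c1ccsc1)cn2[C@@H]1O[C@H](CO)[C@@H](O)[C@H]1O` carries thiophen-3-yl; for compound 3 the read-out in this assay is likewise a limit, > 20000 nM. The steps are therefore an at least 1.3-fold higher number from compound 1 to compound 2 (0.13 log units; that floor lies within the scatter) and an at least 1.3-fold higher number from compound 1 to compound 3 (0.13 log units; that floor lies within the scatter), while the pair of limits gives a step that the two limits leave unreadable from compound 2 to compound 3; that follows from the limit of > 20000 nM in this assay, at which 2 of the 3 values shown sit.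

Compound 4 `O=c1[nH]cnc2c1c(-c1cc3ccccc3o1)cn2[C@@H]1O[C@H](CO)[C@@H](O)[C@H]1O` introduces a larger aryl group: 1-benzofuran-2-yl in place of thiophen-3-yl on an aromatic carbon. Among the measured compounds shown here, no measured step in this set describes a move to a bicyclic aryl group, and the one readable change among the three, from furan-3-yl to either thiophene, only reached the limit. An estimate for compound 4 is therefore a step of an at least 1.3-fold lower number from compound 3 to compound 4 (0.12 log units; that floor lies within the scatter) in this assay, with a fair chance that only a limit is again reported. The expected value for compound 4 is 15000 nM, estimated to lie between 4000 nM and 40000 nM.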

Compound 4, half-maximal inhibitory concentration: > 20000 nM
Compound 4: a limit, no number; the forecaster's own chance of this, stated with the estimate: 50%; middle value at least 1.3-fold (0.12 log units) away from the limit.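

In this assay the 1-benzofuran-2-yl group, which adds a six-membered aromatic ring of carbon only at this position, brings the series no measurable number: compound 4 gives > 20000 nM, which is a limit. Among the compounds shown here, the only step that can be read is an at least 1.3-fold higher number from compound 1 to compound 4 (0.13 log units; that floor lies within the scatter), so the bicyclic group cannot be told apart from furan-3-yl on these data. The steps joining compound 4 to compound 2 and compound 3 cannot be read because both ends of each are limits: the limit of > 20000 nM in this assay, at which 3 of the 4 values shown sit.

The compounds shown leave open whether a group of a different kind on this aromatic carbon, such as an aminomethyl group or a carboxylic acid, would give a number in this assay rather than a limit. They also leave open any order among compound 2, compound 3 and compound 4, and whether any of the three truly differs from compound 1 by more than the usual scatter.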